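Replacing a nitrile with a pyridine on a shared core

This account rests on a few compounds, and the source may have more. Where it says the series, first, only, none or still open, it means among the compounds named here.

Compound 1, `CC1(C)C=C(n2ccccc2=O)c2cc(C=C(C#N)C#N)ccc2O1`, is tested in a functional assay (trachea) with Rattus norvegicus as the target (a lower number here means a less potent compound, a higher number a more potent compound, by a factor of ten per unit of this negative logarithm), and gives 6.3. Compound 2, `CC1(C)C=C(n2ccccc2=O)c2cc(C#N)ccc2O1`, keeps the same core but carries a smaller group on the aromatic carbon, and in this assay compound 2 gives 7.1. Going by the values given here, the single measured step, a number 0.80 log units higher from compound 1 to compound 2 (beyond the scatter), is the only comparison available, and it leaves compound 2 standing highest of the two numbers, with compound 1 as its nearest neighbour.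

Compound 3, `CC1(C)C=C(n2ccccc2=O)c2cc(-c3ccncc3)ccc2O1`, differs from compound 2 at the same aromatic carbon: pyridin-4-yl in place of cyano on an aromatic carbon. Among the compounds with values here, no measured step shows this particular exchange. Within the data shown here, the one step that bears on it, from compound 1 to compound 2, only shows that the larger group at this carbon went with the lower number, while the newly entering ring is different in kind from what left. On that slender basis a modest fall in this assay is expected, and the estimated step for compound 3 is a number 0.50 log units lower from compound 2 to compound 3 (beyond the scatter). Compound 3 is therefore expected to give about 6.6, with a range from 5.9 to 7.3.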

Compound 3, logarithm of the reciprocal of the active concentration, log(1/C): 6.32
The estimate for compound 3 lay 0.28 log units above the measured number, and the stated range covers the measured number.
By their numbers in this assay, from the lowest: compounds 1 and 3 (each within the scatter of the next); then compound 2.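

In this assay, the exchange of the cyano group for pyridin-4-yl gives a number 0.78 log units lower from compound 2 to compound 3 (beyond the scatter), so a second, very different group on this aromatic carbon also falls short of the cyano group. The two replacements cannot be told apart: the step between them is a number 0.02 log units higher from compound 1 to compound 3 (within the scatter), which means that a group containing an aromatic ring and the open-chain 2,2-dicyanoethenyl group give matching numbers here, while cyano alone stands clear of both among these three compounds. No other measurement accompanies these numbers, so the data offer no explanation for the fall from the cyano group.

On these data alone, three groups at one carbon are a thin sample, and it remains open how a single fluorine atom, a plain hydrogen, an amine or a carboxylic acid at this place would compare with the cyano group. As far as these compounds go, it is equally open whether the ring nitrogen of pyridin-4-yl matters to the number, a question that a plain phenyl ring or a pyridin-3-yl ring at the same carbon could help to answer.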